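The compounds below may be only part of what the source reports. "The series", "measured", "known", "first", "only" and "open" are said of these compounds alone.

Compound 1, `N=C(S)CCn1nc(-c2cccs2)ccc1=O`, gives 100 mg/kg in a functional assay on the whole organism (stomach) with Rattus norvegicus as the target; a lower number here means that less compound is needed, a higher number that more compound is needed for the effect. Compound 2, `N=C(S)CCCCCn1nc(-c2ccccc2)ccc1=O`, gives 23.3 mg/kg in this assay.

Compound 2 holds the lower of the two numbers; compound 1 stands beyond the scatter with its higher one. Compound 3, `N=C(S)CCn1nc(-c2ccccc2)ccc1=O`, differs from compound 2 by a group of 3 heavy atoms (1 carbon, 1 nitrogen, 1 sulfur; no ring) in place of a group of 6 heavy atoms (4 carbon, 1 nitrogen, 1 sulfur; no ring), on a saturated chain carbon, two bonds along the chain from an aromatic nitrogen. Among the measured compounds shown here, no measured pair tells the size of this shortening alone. Since compound 1, which shares the shorter chain, gives 100 mg/kg, a step upward from compound 2 is expected. The estimate for compound 3 is 60 mg/kg, within 25 mg/kg to 150 mg/kg, meaning an expected step of a 2.6-fold higher number from compound 2 to compound 3 (0.41 log units; beyond the scatter).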

Compound 3, dose for half-maximal effect: 87.3 mg/kg
Beside the measured number, compound 3's estimate is 1.5-fold (0.16 log units) below it, within the range that was stated.
By their numbers in this assay, from the lowest: compound 2; then compounds 3 and 1 (each within the scatter of the next).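

In this assay the shorter group on the saturated chain carbon gives a 3.7-fold higher number from compound 2 to compound 3 (0.57 log units; beyond the scatter) with the phenyl kept, so this single change raises the number beyond the scatter. Phenyl in place of thiophen-2-yl on the aromatic carbon gives a 1.1-fold lower number from compound 1 to compound 3 (0.06 log units; within the scatter) on the shorter chain, which leaves the two compounds within the scatter. Nothing available explains either step.

From the compounds shown here alone, how a longer chain, or an amine or carboxylic acid in place of the group at this position, would compare remains open. Going by these compounds, whether thiophen-2-yl and phenyl would also match on the longer chain remains open too.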